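A few compounds are considered here, and "the series" means these few. Any claim that something is new, unique, unknown or untested is made for them only; others in the source may bear on it.

In an ADME assay on the whole organism (blood, Mus musculus, strain C57BL/6) for pharmacokinetics, read by HPLC, with a stated time of 4 h, at a dose of 2 mg/kg by the intraperitoneal route (a lower number here means less compound in the circulation, a higher number more compound in the circulation at the dose given), compound 1 (`O=C(Nc1ccc(Cl)c(C(=O)N2CCCCC2)c1O)Nc1cccc(F)c1Cl`) gives "below limit of detection" (no number reported). For the measured compounds named here, compound 2 (`CN1CC[C@H](S(=O)(=O)c2c(Cl)ccc(NC(=O)Nc3cccc(F)c3Cl)c2O)C1`) gives 432 ng.h/mL as the only number so far, so it cannot yet be ranked against a measured neighbour. Compound 3 (`CCN1CCN(S(=O)(=O)c2c(Cl)ccc(NC(=O)Nc3cccc(F)c3Cl)c2O)CC1`) departs from compound 2 on a sulfonyl sulfur (4-ethylpiperazin-1-yl in place of 1-methylpyrrolidin-3-yl on a sulfonyl sulfur), with 4-ethylpiperazin-1-yl in place of 1-methylpyrrolidin-3-yl. Going by the values given here, no measured step bears on this exchange. A small fall is expected (a 1.4-fold lower number from compound 2 to compound 3 (0.16 log units; within the scatter)) that stays within the usual scatter. Compound 3 is estimated at 300 ng.h/mL with a range from 100 ng.h/mL to 900 ng.h/mL as the expected span.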

Compound 3, area under the concentration-time curve: 189 ng.h/mL
Beside the measured number, compound 3's estimate is 1.6-fold (0.20 log units) above it, and the stated range covers the measured number.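

In this assay, for the compounds shown here, the exchange of 1-methylpyrrolidin-3-yl for 4-ethylpiperazin-1-yl on a sulfonyl sulfur reads as a 2.3-fold lower number from compound 2 to compound 3 (0.36 log units; beyond the scatter) and gives the first readable step at this position. It shows that the group on the sulfonyl sulfur bears on the read-out, though the step is modest and both compounds still give numbers. Nothing offered here accounts for the step.

Still open, as far as these compounds go, is whether the ring or the ethyl chain carries the step, since both change together. A 4-methylpiperazin-1-yl group at this place would separate the two.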